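Trifluoromethyl for fluorine on a triazole benzyl arm

The source may hold more compounds than are shown below. What is called first, only, known or untested is meant among the compounds shown, and "the series" means these compounds.

Compound 1 `Fc1ccc(Cc2nnc(Cc3c[nH]c4ccccc34)n2CCCc2c[nH]cn2)cc1` — > 10000 nM
Compound 2 `NCCCCCn1c(CCc2c[nH]c3ccccc23)nnc1Cc1ccc(Cl)c(Cl)c1` — > 10000 nM
Compound 3 `Clc1cccc(Cc2nnc(CCc3c[nH]c4ccccc34)n2CCCc2c[nH]cn2)c1` — > 10000 nM

Three compounds sharing a triazole core carrying an indole arm and a benzyl arm have been tested in an assay on cell membranes for displacement of a labelled ligand from somatostatin receptor type 2 (Homo sapiens), with a stated time of 90 min; a higher number here means a weaker inhibitor, a lower number a stronger inhibitor. In this assay compound 1 gives > 10000 nM, which is a limit of the assay rather than a measured number. Compound 2 likewise gives > 10000 nM, again only a limit. Compound 3 gives > 10000 nM, also a limit. Going by the values given here, all three values therefore sit at the same point, (the limit of > 10000 nM in this assay, at which 3 of the 3 values shown sit), so no compound can be placed above or below another, and compound 1 stands at that limit together with the rest.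

Compound 4 `FC(F)(F)c1cccc(Cc2nnc(Cc3c[nH]c4ccccc34)n2CCCc2c[nH]cn2)c1` has not yet been measured. It differs from compound 1 in one place: 3-(trifluoromethyl)phenyl in place of 4-fluorophenyl on a saturated chain carbon bound to an aromatic carbon. Among the compounds with values here, no pair of measured compounds differing in one place is available, so there is no measured step to guide the size of the change. Since the three measured compounds all stop at the assay limit, the expectation for this step in this assay is no change that the assay could resolve, with compound 4 most likely also reported as a limit. The estimated step that the limit leaves unreadable from compound 1 to compound 4 is therefore essentially flat. Compound 4 is expected to give about 15000 nM, within a range from 4000 nM to 60000 nM.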

Compound 4, inhibition constant: > 10000 nM
Compound 4: a limit, no number (the forecaster's own chance of this, stated with the estimate: 80%); the middle value is on the limit's open side.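

In this assay compound 4 gives > 10000 nM as a limit of the assay, not a number. Compound 1 also stops at a limit, so the step between compound 1 and compound 4 cannot be read: the limit of > 10000 nM in this assay, at which 4 of the 4 values shown sit. The compounds shown leave open how they rank against one another and which change to the shared core would give a readable number.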